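Same atoms, joined differently: from compound 1 to compound 3

The compounds below may be only part of what the source reports. "The series", "measured", "known", "first", "only" and "open" are said of these compounds alone.

Within the data shown here, in a functional assay on OVCAR-3 cells (Homo sapiens) for cytotoxicity, read by sulforhodamine B assay (on this read-out lower numbers stand for higher toxicity in this test and higher numbers for lower toxicity in this test), compound 1 `CC1=CC[C@@H]([C@@](C)(O)CCCC(C)(C)NC(=S)N/N=C\c2ccc(C)cc2)CC1` gives 45300 nM, the only true number so far. Compound 2 `CC1=CC[C@@H]([C@@](C)(O)CCCC(C)(C)NC(=S)N/N=C\c2ccc([N+](=O)[O-])cc2)CC1` gives > 100000 nM, which is a limit of the assay. Compound 3 `CC1=CC[C@@H]([C@@](C)(O)CCCC(C)(C)NC(=S)N/N=C(/C)c2ccccc2)CC1` has the same atoms as compound 1, joined differently: a group of 9 heavy atoms (8 carbon, 1 nitrogen; one six-membered aromatic ring of carbon only) in place of a group of 9 heavy atoms (8 carbon, 1 nitrogen; one six-membered aromatic ring of carbon only), on an amide-type nitrogen. Among the measured compounds shown here, the only measured step, an at least 2.2-fold higher number from compound 1 to compound 2 (0.34 log units; beyond the scatter), puts nitro in place of methyl on an aromatic carbon, so it is a different kind of change and offers only loose guidance. The expected step is therefore small, a 1.1-fold higher number from compound 1 to compound 3 (0.04 log units; within the scatter), within the usual scatter. For compound 3 the estimated value is 50000 nM, with a range of 20000 nM to 100000 nM.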

Compound 3, concentration lethal to 50% of the cells: > 100000 nM
Compound 3: only a limit was reported; the forecaster's own chance of this, stated with the estimate: 25%; middle value at least 2.0-fold (0.30 log units) away from the limit.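

Rejoining the same atoms on the amide-type nitrogen, with no change in the counts of rings, donors or acceptors, is enough to give an at least 2.2-fold higher number from compound 1 to compound 3 (0.34 log units; beyond the scatter), so this position responds to more than a swap of nitro for methyl. In this assay, from the compounds shown here alone, compound 3 gives > 100000 nM, which is a limit and not a number, so the true size of the step stays unknown. Compounds 2 and 3 cannot be ordered against each other: the limit of > 100000 nM in this assay, at which 2 of the 3 values shown sit.

Going by these compounds, whether any group on this nitrogen gives a lower number than compound 1 remains open. So does the effect of a chloro on the aromatic ring or a longer chain in place of the methyl.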